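Chain Length and Leukotriene Receptor Inhibition in Cyano Ethers

A few compounds are considered here, and "the series" means these few. Any claim that something is new, unique, unknown or untested is made for them only; others in the source may bear on it.

Three compounds share a core and differ only in the length of a nitrile-bearing chain on an aromatic oxygen. Compound 1, `C=CCc1cc(C(C)=O)c(O)cc1OCC#N`, carries the shortest chain. In an assay on isolated protein for inhibition of leukotriene B4 receptor 1 (Homo sapiens), tested at 10 uM (on this read-out lower numbers stand for less inhibition and higher numbers for more inhibition at the one concentration tested (going by the name of the read-out)), compound 1 gives 20%. Compound 2, `C=CCc1cc(C(C)=O)c(O)cc1OCCCC#N`, differs from it by 2-cyanoethyl in place of cyano on a saturated chain carbon bound to an oxygen on an aromatic ring, and in this assay compound 2 gives 47%, so that the step of a number 27 percentage points higher from compound 1 to compound 2 (beyond the scatter) is recorded. Compound 3, `C=CCc1cc(C(C)=O)c(O)cc1OCCCCCCCCC#N`, carries the longest chain of the measured set and gives 86% in this assay; the step of a number 39 percentage points higher from compound 2 to compound 3 (beyond the scatter) follows. Compound 3 thus stands highest of the three measured compounds, with its steps to compound 2 and to compound 1 both beyond the scatter. The difference between the cores of compound 1 and compound 3 is not broken down here.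

Compound 4, `C=CCc1cc(C(C)=O)c(O)cc1OCCCCCCCCCCC#N`, has not yet been measured. It differs from compound 3 by 2-cyanoethyl in place of cyano on a saturated chain carbon, eight bonds along the chain from an oxygen on an aromatic ring. Within the data shown here, this is the same kind of change as the one from compound 1 to compound 2, but the place is not identical: there the change sat on a saturated chain carbon bound to an oxygen on an aromatic ring, here it sits eight bonds along the chain from an oxygen on an aromatic ring. Each lengthening so far has raised the inhibition, yet the room left is small because compound 3 already gives 86%. A step of about a number 4 percentage points higher from compound 3 to compound 4 (within the scatter) is therefore expected, smaller than the earlier ones. Compound 4 is estimated to give 90% in this assay, with a likely range from 76% to 100%.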

Compound 4, a percentage reported as inhibition, at one concentration (the size of the read-out at that concentration, not a potency): 50%
Compound 4: the middle estimate sits 40 percentage points above what was measured, outside the stated range (below it).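

In this assay the exchange of cyano for 2-cyanoethyl, eight bonds along the chain from an oxygen on an aromatic ring, gives a number 36 percentage points lower from compound 3 to compound 4 (beyond the scatter), so the rise seen when the same exchange was made on the shortest chain does not carry over to the core of compound 3. Compound 4 thus goes against the climb in inhibition that runs through compound 1, compound 2 and compound 3, and the two cases of this change point in opposite directions: the same change on two cores in this assay, a number 27 percentage points higher (beyond the scatter) from compound 1 to compound 2 and a number 36 percentage points lower (beyond the scatter) from compound 3 to compound 4, 63 percentage points apart, beyond the scatter of two such steps This shows that, in this series, the result of the change on one core cannot simply be taken over to another, but two pairs do not show at what chain length the turn comes, nor why inhibition falls.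

The compounds shown leave open how a chain of intermediate length between those of compound 3 and compound 4 would read, whether a still longer chain would fall further, and whether a carboxylic acid or an amine at the chain end in place of the nitrile would follow the same course. They also leave open whether the reversal would hold with other groups on the shared core.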